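Replacing the sulfonamide on the amine nitrogen of compound 3

The source may hold more compounds than are shown below. What is called first, only, known or untested is meant among the compounds shown, and "the series" means these compounds.

Measured so far in a functional assay (muscle tissue) for inhibition, with Homo sapiens as the target; a higher number here means a weaker inhibitor, a lower number a stronger inhibitor:
compound 1 `O=C(N[C@@H](CCC(=O)N1CCN(c2cccc(NC3=NCCCN3)c2)CC1)C(=O)O)OCc1ccccc1` gives 1.1 nM
compound 2 `CC(C)COC(=O)N[C@@H](CCC(=O)N1CCN(c2cccc(NC3=NCCCN3)c2)CC1)C(=O)O` gives 0.91 nM
compound 3 `O=C(O)[C@H](CCC(=O)N1CCN(c2cccc(NC3=NCCCN3)c2)CC1)NS(=O)(=O)c1ccccc1` gives > 10 nM

Compound 3 stands apart from the other two: its value in this assay is a limit, not a number, and it sits at the limit of > 10 nM in this assay, at which 1 of the 3 values shown sits. The two measured steps leading to it, an at least 9.0-fold higher number from compound 1 to compound 3 (0.95 log units; beyond the scatter) and an at least 10-fold higher number from compound 2 to compound 3 (1.04 log units; beyond the scatter), both run in the same direction and both lie beyond the scatter, while a 1.2-fold lower number from compound 1 to compound 2 (0.08 log units; within the scatter) lies within it.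

Compound 4 `CCNC(=O)N[C@@H](CCC(=O)N1CCN(c2cccc(NC3=NCCCN3)c2)CC1)C(=O)O` differs from compound 3 by ethylcarbamoyl in place of phenylsulfonyl on an amine nitrogen. This undoes the phenylsulfonyl that both measured steps point to as the weaker choice, and puts in its place a carbonyl-bearing group on the amine nitrogen, as in compound 1 and compound 2. A step back toward their values is therefore expected, of about the size seen in those two steps but in the opposite direction; the step from compound 3 to compound 4 is estimated as an at least 5.0-fold lower number from compound 3 to compound 4 (0.69 log units; beyond the scatter). For compound 4 in this assay the expected value is 2 nM, with a range from 0.7 nM to 8 nM.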

Compound 4, half-maximal inhibitory concentration: > 10 nM
Compound 4: no number, only a limit; the forecaster's own chance of this, stated with the estimate: 15%; middle value at least 5.0-fold (0.69 log units) from the limit.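

In this assay compound 4 gives > 10 nM, a limit and not a number: the limit of > 10 nM in this assay, at which 2 of the 4 values shown sit.

Ethylamino in place of isobutoxy on the carbonyl carbon gives an at least 10-fold higher number from compound 2 to compound 4 (1.04 log units; beyond the scatter), and ethylamino in place of benzyloxy gives an at least 9.0-fold higher number from compound 1 to compound 4 (0.95 log units; beyond the scatter). A carbonyl-bearing group on this amine nitrogen is therefore not enough on its own: of the groups shown here, only the isobutoxycarbonyl of compound 2 and the benzyloxycarbonyl of compound 1 give measured numbers.

Going by these compounds, the step between compound 3 and compound 4 cannot be read, as both values are limits, so their order stays open. Also open, on these data alone, is whether acetyl on the amine nitrogen, or benzyl in place of the ethyl of ethylcarbamoyl, would come back to the range of compound 1 and compound 2.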